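Swapping an Alkyl Chain for a Glycyl Group

The source may report more compounds than this note shows. Statements on the series, on what has been measured and on what is new or still open speak of the compounds shown alone.

Of the compounds shown here, three sharing a sulfonamide-linked core have been tested in an assay on VSM-A10 cells for antagonist activity at Endothelin-1 receptor (Rattus norvegicus); on this read-out lower numbers stand for stronger inhibition and higher numbers for weaker inhibition. Compound 1, `CCCNc1ccc(S(=O)(=O)Nc2onc(C)c2C)cc1`, gives 27000 nM, the highest number of the three and thus the weakest inhibitor. Compound 2, `CCOC(=O)C(C)Nc1cccc2c(S(=O)(=O)Nc3onc(C)c3C)cccc12`, gives 400 nM, and compound 3, `Cc1noc(NS(=O)(=O)c2cccc3c(NC(=O)C(C)C)cccc23)c1C`, gives 880 nM; both sit on a larger core than compound 1 and carry a carbonyl-bearing group on the ring nitrogen. Going by the values given here, the only single-point step among the measured compounds is a 2.2-fold higher number from compound 2 to compound 3 (0.34 log units; beyond the scatter), which shows that exchanging one carbonyl-bearing substituent for another on that nitrogen moves the number only modestly.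

Compound 4, `Cc1noc(NS(=O)(=O)c2ccc(NC(=O)CN)cc2)c1C`, keeps the core of compound 1 and differs from it in one place: (aminomethyl)carbonyl in place of propyl on a nitrogen on an aromatic ring. The change introduces a carbonyl and a further nitrogen where compound 1 has only a plain chain. Among the compounds with values here, no measured step isolates this exact exchange on this core; the step from compound 2 to compound 3 is the nearest guide and was modest, while the far lower numbers of compounds 2 and 3 against compound 1 mix a core change with the substituent change. A lower number than compound 1 is therefore expected, but of uncertain size, and compound 4 is estimated at 10000 nM, within 2000 nM to 50000 nM, meaning a step of a 2.7-fold lower number from compound 1 to compound 4 (0.43 log units; beyond the scatter).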

Compound 4, half-maximal inhibitory concentration: 6500 nM
Compound 4: middle estimate off by 1.5-fold (0.19 log units), on the high side, and the stated range covers the measured number.
By their numbers in this assay, from the lowest: compound 2; then compound 3; then compound 4; then compound 1.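

Going by these compounds alone, on the core of compound 1, putting (aminomethyl)carbonyl in place of propyl gives a 4.2-fold lower number from compound 1 to compound 4 (0.62 log units; beyond the scatter) in this assay, and this is the first step that changes the group on this nitrogen while the core stays fixed. Within the data shown here, until now, the only single-place step at such a nitrogen came from compounds 2 and 3, which both carry a carbonyl-bearing group on a larger core, whereas here a plain chain with no hydrogen-bond donors or acceptors gives way to a group that has both, and the number falls rather than rises. No supporting measurement is available to explain why the number moves in this direction.

From the compounds shown here alone, the new group differs from propyl in both its carbonyl and its amine, so it remains open which of the two goes with the lower number; a plain acetyl group, which keeps the carbonyl but has no amine, would help separate them, as would a longer chain between the carbonyl and the amine. Going by these compounds, it also remains open whether (aminomethyl)carbonyl would give a step of similar size on the larger core of compounds 2 and 3.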